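A few compounds are considered here, and "the series" means these few. Any claim that something is new, unique, unknown or untested is made for them only; others in the source may bear on it.

Measured compounds in a functional assay on DLD-1 cells (Homo sapiens) for antiproliferative activity, read by CellTiter-Glo, with a stated time of 72 h; a lower number here means a stronger inhibitor, a higher number a weaker inhibitor:
- compound 1, `CC1CCN(C2CCN(S(=O)(=O)c3ccc(-c4ccccc4F)cc3)CC2)CC1`: 5 nM
- compound 2, `C#CCCC(=O)CC1CCN(C2CCN(S(=O)(=O)c3c(C)cc(C)cc3C)CC2)CC1`: 3 nM

On these two numbers compound 1 stands highest, but its nearest neighbour is compound 2 and the gap between them lies within the usual scatter, so no order between the two can be read from the data. Both compounds share the core of compound 1 and differ at several places at once, so no single change can be traced between them.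

Compound 3, `CC1CCN(C2CCN(S(=O)(=O)c3ccc(C(C)(C)C)cc3)CC2)CC1`, is not yet measured in this assay. Relative to compound 1 it carries one change: tert-butyl in place of 2-fluorophenyl on an aromatic carbon. Going by the values given here, no measured pair shows this change, so its size cannot be taken from a known step. What the data do show is that compound 2, which carries no 2-fluorophenyl on its sulfonyl-bearing ring, gives 3 nM, a number of the same size as compound 1. The expectation is therefore a step of a 1.6-fold higher number from compound 1 to compound 3 (0.20 log units; within the scatter), at most a mild weakening and possibly none beyond the scatter. Compound 3 is estimated at 8 nM, in the range 2 nM to 30 nM.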

Compound 3, half-maximal inhibitory concentration: > 5000 nM
Compound 3 ended at the assay's limit (the forecaster's own chance of this, stated with the estimate: 2%); middle value at least 620-fold (2.79 log units) from the limit.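

In this assay, going by these compounds alone, the exchange of 2-fluorophenyl for tert-butyl on an aromatic carbon, para to a large group, gives an at least 1000-fold higher number from compound 1 to compound 3 (3.00 log units; beyond the scatter), and this is the first step that can be read as a single change. On these data alone, for compound 3 the reading is a limit of the assay and not a number, so the step has no upper end and its full size stays unknown: the limit of > 5000 nM in this assay, at which 1 of the 3 values shown sits. The position is therefore not indifferent to the group it carries, even though the two groups match in their counts of hydrogen-bond donors and acceptors and differ in heavy atoms and in the six-membered aromatic ring of carbon only, which leaves with 2-fluorophenyl.

The compounds shown do not separate the ring from its fluorine, and a plain phenyl or a cyclohexyl group at this place would tell the two apart. As far as these compounds go, how an amine, a carboxylic acid or a smaller group such as methoxy would read at this place in this assay also remains open.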